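The compounds below may be only part of what the source reports. "The series", "measured", "known", "first", "only" and "open" are said of these compounds alone.

Measured in an ADME assay on L6 cells (Rattus norvegicus) for cytotoxicity, read by resazurin assay, with a stated time of 72 h; a lower number here means a stronger inhibitor, a higher number a weaker inhibitor:
- compound 1 `O=[N+]([O-])c1cn2c(n1)OC[C@H](OCc1ccc(-c3ccc(OC(F)(F)F)cc3Cl)cc1)C2` gives 25000 nM
- compound 2 `O=[N+]([O-])c1cn2c(n1)OC(COc1ccc(-c3ccc(OC(F)(F)F)cc3)nn1)CC2` gives 42000 nM

Compound 1 stands level with compound 2, since their two values lie within the scatter of each other. Among the compounds with values here, compound 3 `O=[N+]([O-])c1cn2c(n1)OC[C@@H](OCc1ccc(-c3ccc(OC(F)(F)F)cc3Cl)cc1)C2` has the same atoms and bonds as compound 1, and the only change is the two compounds have the same atoms and bonds and differ only in configuration as drawn: 1 of 1 stereo elements differ; a stereocentre at a saturated ring carbon is drawn R in compound 1 and S in compound 3 in the drawn configuration. Within the data shown here, no measured pair shows what such a change does in this assay, so no step beyond the scatter is expected, in either direction. The expected step is no change at the digits printed from compound 1 to compound 3 (within the scatter) in this estimate. Compound 3 is estimated at 25000 nM, within an expected range of 12000 nM to 50000 nM.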

Compound 3, half-maximal inhibitory concentration: 19000 nM
Estimate against measurement, compound 3: 1.3-fold (0.12 log units) above; the measured number falls inside the stated range.
By their numbers in this assay, from the lowest: compounds 3, 1 and 2 (each within the scatter of the next, the first and the last beyond it).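

Within the data shown here, this pair gives the first direct reading of the configuration at this saturated ring carbon, which compounds 1 and 2 alone could not give. In this assay, redrawing the stereocentre from R to S gives a 1.3-fold lower number from compound 1 to compound 3 (0.12 log units; within the scatter), so this assay does not separate the two configurations. The comparison is a clean one for this stereocentre: the fact that compounds 1 and 3 differ only in the configuration as drawn

The compounds shown leave open whether the configuration at this carbon would still make so little difference if the side chain carried an amine or a carboxylic acid.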